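This account rests on a few compounds, and the source may have more. Where it says the series, first, only, none or still open, it means among the compounds named here.

Of the compounds shown here, three of a shared core have been measured in an assay on cells for inhibition of cytochrome P450 11B2, mitochondrial (Homo sapiens); on this read-out lower numbers stand for stronger inhibition and higher numbers for weaker inhibition. Compound 1 `CC(C)CC1n2cncc2CN(CC2CC2)S1(=O)=O` carries a cyclopropylmethyl group on the sulfonamide nitrogen and gives 758 nM. Compound 2 `CC(C)CC1n2cncc2CN(Cc2ccc(OC(F)(F)F)cc2)S1(=O)=O` carries a benzyl group bearing a trifluoromethoxy substituent and gives 104 nM. Compound 3 `C[C@@H](c1ccc(Cl)cc1)N1Cc2cncn2C(CC2(C)COC2)S1(=O)=O`, which has a chloro-substituted phenylethyl group on the nitrogen and a (3-methyloxetan-3-yl)methyl chain on the ring carbon, gives 7.8 nM. Compound 3 thus stands lowest of the three values in this assay, with compound 2 as its nearest neighbour and compound 1 furthest away, both differences lying beyond the scatter.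

Compound 4 `C[C@@H](c1ccc(Cl)cc1)N1Cc2cncn2C(C[C@H](O)c2ccccc2)S1(=O)=O` has not yet been measured. It differs from compound 3 in one place: hydroxy(phenyl)methyl in place of 3-methyloxetan-3-yl on a saturated chain carbon bound to a saturated ring carbon. Going by the values given here, no pair of measured compounds shows this particular change, so there is no measured step to lean on. Because compound 3 already reaches 7.8 nM and the chain is altered rather than removed, a step of modest size is expected for the move from compound 3 to compound 4, a 1.9-fold higher number from compound 3 to compound 4 (0.28 log units; within the scatter), toward a somewhat higher value, though one within the scatter cannot be excluded. For compound 4 the expected value in this assay is estimated at 15 nM, with a range from 4 nM to 60 nM.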

Compound 4, half-maximal inhibitory concentration: 0.3 nM
For compound 4 the middle estimate is 50-fold (1.70 log units) above the measured one, outside the stated range (below it).
By their numbers in this assay, from the lowest: compound 4; then compound 3; then compound 2; then compound 1.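

In this assay, going by these compounds alone, the chain on the saturated ring carbon turns out to be a place where one change alone moves the number strongly: hydroxy(phenyl)methyl in place of 3-methyloxetan-3-yl gives a 26-fold lower number from compound 3 to compound 4 (1.41 log units; beyond the scatter), the first single-place step, since compounds 1, 2 and 3 differ from one another in more than one place. It also shows that this position accepts a larger group than 3-methyloxetan-3-yl without any loss, and that the strong inhibition seen with compound 3 was not a limit for this chain. The entering group brings a six-membered aromatic ring of carbon only, a hydrogen-bond donor and a defined stereocentre all at once, and nothing available explains the size of the step.

The compounds shown leave open which of these features carries the step: a 2-phenylethyl chain with no hydroxy group, an amine in place of the hydroxy group, or the opposite configuration at the stereocentre would each separate them. They also leave open whether the step would recur with the cyclopropylmethyl group of compound 1 on the sulfonamide nitrogen.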